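A few compounds are considered here, and "the series" means these few. Any claim that something is new, unique, unknown or untested is made for them only; others in the source may bear on it.

Values in a functional assay on PC-3 cells (Homo sapiens) for antiproliferative activity, read by MTT assay, with a stated time of 24 h; on this read-out higher numbers stand for weaker inhibition and lower numbers for stronger inhibition:
- compound 1 `CCn1c(C(=O)NCC(=O)OC)ccc1C(CC)(CC)c1ccc(OCS(=O)(=O)c2ccccc2)c(C)c1`: > 50000 nM, a limit of the assay
- compound 2 `CCn1c(C(=O)NC(C)(C)CO)ccc1C(CC)(CC)c1ccc(OCS(=O)(=O)c2ccccc2)c(C)c1`: 9850 nM
- compound 3 `CCn1c(C(=O)N[C@H](CO)CCO)ccc1C(CC)(CC)c1ccc(OCS(=O)(=O)c2ccccc2)c(C)c1`: 12100 nM

Compound 1 has only a limit: the limit of > 50000 nM in this assay, at which 1 of the 3 values shown sits.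

Compound 3 stands within the scatter of compound 2, so the two measured numbers do not separate. Replacing (methoxycarbonyl)methyl on the amide-type nitrogen gave an at least 5.0-fold lower number from compound 1 to compound 2 (0.70 log units; beyond the scatter). The other replacement at that nitrogen gave an at least 4.1-fold lower number from compound 1 to compound 3 (0.61 log units; beyond the scatter). Both steps start from a limit and involve a larger exchange than the one considered here.

Compound 4 `CCn1c(C(=O)N[C@H](CO)CCCO)ccc1C(CC)(CC)c1ccc(OCS(=O)(=O)c2ccccc2)c(C)c1` differs from compound 3 by one change: hydroxymethyl in place of hydroxy on a saturated chain carbon, three bonds along the chain from an amide-type nitrogen. This places hydroxymethyl in place of hydroxy on a saturated chain carbon, three bonds along the chain from an amide-type nitrogen. Cut one bond further out, it reads 2-hydroxyethyl to 3-hydroxypropyl.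

Within the data shown here, no measured step isolates this chain extension. The closest guide is the exchange between the two hydroxy-bearing groups, a 1.2-fold higher number from compound 2 to compound 3 (0.09 log units; within the scatter), which stayed within the scatter. On that basis, no step beyond the scatter is expected in this assay.

The expected step is a 1.1-fold lower number from compound 3 to compound 4 (0.02 log units; within the scatter).

Compound 4 is estimated at 11500 nM, with an expected range of 5500 nM to 25000 nM.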

Compound 4, half-maximal inhibitory concentration: 6810 nM
Beside the measured number, compound 4's estimate is 1.7-fold (0.23 log units) above it; the range from low to high includes it.
By their numbers in this assay, from the lowest: compounds 4, 2 and 3 (each within the scatter of the next). At a limit, above all of these: compound 1.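

In this assay, among these compounds, hydroxymethyl in place of hydroxy on a saturated chain carbon, three bonds along the chain from an amide-type nitrogen, gives a 1.8-fold lower number from compound 3 to compound 4 (0.25 log units; within the scatter); this is the first step to isolate the extension of 2-hydroxyethyl to 3-hydroxypropyl, and at this position it does not separate the two compounds. The wider exchange on the amide-type nitrogen also stays unresolved, with a 1.4-fold lower number from compound 2 to compound 4 (0.16 log units; within the scatter), so the three hydroxy-bearing compounds 2, 3 and 4 all lie within the scatter of one another. The only step from this result that is beyond the scatter is an at least 7.3-fold lower number from compound 1 to compound 4 (0.86 log units; beyond the scatter), and it starts from a limit, so its true size is not known: the limit of > 50000 nM in this assay, at which 1 of the 4 values shown sits.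

Going by these compounds, whether a longer chain such as 4-hydroxybutyl, or an amine or a carboxylic acid in place of the terminal hydroxy, would move the number beyond the scatter remains open. Also open, on these data alone, is where carboxymethyl, the free acid counterpart of the (methoxycarbonyl)methyl group of compound 1, would stand in this assay.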